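The source may report more compounds than this note shows. Statements on the series, on what has been measured and on what is new or still open speak of the compounds shown alone.

Measured so far:
- compound 1 `CCn1nc(C)cc1C(=O)Nc1nc2cc(C(N)=O)cc(OC)c2n1CCCNC(=O)C(C)(C)C`: > 100000 nM
- compound 2 `CCn1nc(C)cc1C(=O)Nc1nc2cc(C(N)=O)cc(OC)c2n1CCCNC(=O)c1ccccc1`: > 100000 nM

In an assay for activation of interferon regulatory factor 3 (Homo sapiens), read by a luciferase reporter, with a stated time of 20 h (a lower number here means that less compound is needed, a higher number that more compound is needed for the effect), compound 1 gives > 100000 nM, which is a limit of the assay and not a number. Compound 2 gives > 100000 nM in this assay, likewise a limit. The step that the two limits leave unreadable from compound 1 to compound 2 is therefore unreadable. Compound 2 stands where both values shown sit: the limit of > 100000 nM in this assay, at which 2 of the 2 values shown sit.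

Compound 3 `CCn1nc(C)cc1C(=O)Nc1nc2cc(C(N)=O)cc(OC)c2n1CCCNC(=O)CCc1cccnc1` differs from compound 2 in one place: 2-(pyridin-3-yl)ethyl in place of phenyl on a carbonyl carbon. For the measured compounds named here, the only measured step that bears on this position is the unreadable one from compound 1 to compound 2, so no direction beyond the scatter can be drawn from it. Compound 3 is expected to remain around the limit, with an estimate of 100000 nM (range 30000 nM to 300000 nM). The expected step is a number no higher from compound 2 to compound 3 (the limit leaves the size open), most likely reported again as a limit.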

Compound 3, half-maximal effective concentration: > 100000 nM
Compound 3: only a limit was reported (the forecaster's own chance of this, stated with the estimate: 80%); the middle value lies on the limit itself.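

In this assay compound 3 gives > 100000 nM, a limit of the assay and not a number, so its steps from compound 1 and compound 2 cannot be read. The compounds shown leave open whether any group on this carbonyl carbon gives a measurable effect, since all sit at one value: the limit of > 100000 nM in this assay, at which 3 of the 3 values shown sit.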